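This account rests on a few compounds, and the source may have more. Where it says the series, first, only, none or still open, it means among the compounds named here.

Compound 1 `Fc1ccc(C2=NN(C(=S)Nc3ccccc3)C(c3ccc4c(c3)OCCO4)C2)cc1` is built on a shared core that carries a 4-fluorophenyl group on a carbon with a double bond to nitrogen. In a functional assay on HT-29 cells (Homo sapiens) for antiproliferative activity, read by MTT assay, with a stated time of 48 h (on this read-out lower numbers stand for stronger inhibition of growth and higher numbers for weaker inhibition of growth), compound 1 gives 37600 nM. Among the results shown this is the only true number, since the other entry is a limit of the assay. Compound 2 `S=C(Nc1ccccc1)N1N=C(c2ccccc2Br)CC1c1ccc2c(c1)OCCO2` carries 2-bromophenyl in the same place. For compound 2 this assay reports only a limit, > 200000 nM. The step of an at least 5.3-fold higher number from compound 1 to compound 2 (0.72 log units; beyond the scatter) shows that exchanging the group here can weaken growth inhibition, and one of the two values shown sits at the limit of > 200000 nM in this assay, at which 1 of the 2 values shown sits.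

Compound 3 `COc1cccc(C2=NN(C(=S)Nc3ccccc3)C(c3ccc4c(c3)OCCO4)C2)c1` is not yet measured; it differs from compound 1 by 3-methoxyphenyl in place of 4-fluorophenyl on a carbon with a double bond to nitrogen. Within the data shown here, only one measured step, the one from compound 1 to compound 2, touches this place, and it was at least modest in the weakening direction. A related exchange at the same place is therefore expected to give a step of a 1.5-fold higher number from compound 1 to compound 3 (0.17 log units; within the scatter), with weaker inhibition somewhat more likely than stronger. Compound 3 is accordingly estimated at 55000 nM, between 15000 nM and 200000 nM.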

Compound 3, concentration for 50% growth inhibition: 2920 nM
The estimate for compound 3 lay 19-fold (1.27 log units) above the measured number; measured number outside the range, below it.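

The place on the carbon with a double bond to nitrogen had so far shown only that an exchange can weaken growth inhibition, but it can also strengthen it: in this assay, 3-methoxyphenyl in place of 4-fluorophenyl gives a 13-fold lower number from compound 1 to compound 3 (1.11 log units; beyond the scatter). Replacing 2-bromophenyl with 3-methoxyphenyl at the same place gives an at least 68-fold lower number from compound 2 to compound 3 (1.83 log units; beyond the scatter), so among these three compounds the choice of substituted phenyl group moves the result strongly in both directions. This second step has an open end, because compound 2 gives only a limit of the assay and not a number: the limit of > 200000 nM in this assay, at which 1 of the 3 values shown sits.

On these data alone, whether the gain goes with the methoxy group itself or with its place on the ring stays open, and a 4-methoxyphenyl or a 3-fluorophenyl group at this position would be needed to tell the two apart. The data do not tell what lies behind the gain. They also do not show how a group with a free hydrogen, such as 3-hydroxyphenyl or 3-aminophenyl, would behave here.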